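Acrylonitrile amides: furan-3-yl to 4-chlorophenyl

The source may report more compounds than this note shows. Statements on the series, on what has been measured and on what is new or still open speak of the compounds shown alone.

Measured so far in a functional assay on HT-29 cells (Homo sapiens) for inhibition, read by MTT assay, with a stated time of 72 h; on this read-out higher numbers stand for weaker inhibition of growth and lower numbers for stronger inhibition of growth:
- compound 1, `COc1ccc(CNC(=O)/C(C#N)=C/c2ccc[nH]2)cc1`: > 50000 nM (a limit of the assay)
- compound 2, `COc1ccc(CNC(=O)/C(C#N)=C/c2ccc(C)o2)cc1`: 92000 nM
- compound 3, `COc1ccc(CNC(=O)/C(C#N)=C/c2ccoc2)cc1`: 6000 nM

Compound 3 holds the lowest number shown in this assay, with compound 2 nearest at a 15-fold lower number from compound 2 to compound 3 (1.19 log units; beyond the scatter). For compound 1 only a limit is known, (the limit of > 50000 nM in this assay, at which 1 of the 3 values shown sits), so the step that the limit leaves unreadable from compound 1 to compound 2 cannot be sized, whereas an at least 8.3-fold lower number from compound 1 to compound 3 (0.92 log units; beyond the scatter) is readable. Both readable steps are swaps of one five-membered ring for another, and both are large.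

Compound 4, `COc1ccc(CNC(=O)/C(C#N)=C/c2ccc(Cl)cc2)cc1`, differs from compound 3 by 4-chlorophenyl in place of furan-3-yl on a double-bonded chain carbon bound to a double-bonded chain carbon. Among the compounds with values here, none of the measured steps involves a six-membered carbon ring, so no step bears directly on this change; the measured steps only show that the ring on this chain carbon moves the number strongly in either direction. The expectation for compound 4 in this assay is therefore wide: a step of a 1.7-fold higher number from compound 3 to compound 4 (0.22 log units; within the scatter) is estimated, towards a weaker inhibition of growth but with the range covering no change.

Compound 4 is expected to give about 10000 nM, between 1500 nM and 50000 nM.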

Compound 4, concentration for 50% growth inhibition: 7000 nM
Compound 4: middle estimate off by 1.4-fold (0.15 log units), on the high side; measured number inside the range.
By their numbers in this assay, from the lowest: compounds 3 and 4 (each within the scatter of the next); then compound 2.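

In this assay, a six-membered carbon ring on a double-bonded chain carbon bound to a double-bonded chain carbon reads the same as the best five-membered ring shown: a 1.2-fold higher number from compound 3 to compound 4 (0.07 log units; within the scatter), so 4-chlorophenyl and furan-3-yl cannot be told apart here, despite the different ring size and the loss of the ring oxygen. Measured against the other two rings, 4-chlorophenyl gives a 13-fold lower number from compound 2 to compound 4 (1.12 log units; beyond the scatter) and an at least 7.1-fold lower number from compound 1 to compound 4 (0.85 log units; beyond the scatter), so a low number at this position is not confined to five-membered rings, while the 5-methylfuran-2-yl of compound 2 and the 1H-pyrrol-2-yl of compound 1 show that a five-membered ring does not ensure one. The last of these steps has only a minimum size, since compound 1 carries a limit and not a number: the limit of > 50000 nM in this assay, at which 1 of the 4 values shown sits.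

Open, as far as these compounds go, is how a phenyl ring carrying an amine or a carboxylic acid in place of the chlorine would read in this assay. Also open, from the compounds shown here alone, is whether the level shared by compound 3 and compound 4 would hold with a carboxylic acid in place of the nitrile.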